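Series notes: N-substituent change on the benzylamine of the core

The compounds below may be only part of what the source reports. "The series", "measured", "known", "first", "only" and "open" are said of these compounds alone.

Compound 2 `COc1cc(Oc2cccc(Nc3ccccc3)c2)cc(OC)c1CNC1CC1` carries a cyclopropyl on the amine nitrogen. In a functional assay on SW-620 cells (Homo sapiens) for inhibition, read by MTT assay, with a stated time of 72 h (on this read-out lower numbers stand for stronger inhibition and higher numbers for weaker inhibition), compound 2 gives > 20000 nM, a limit of the assay and not a number. For the measured compounds named here, compound 1 `COc1cc(Oc2cccc(Nc3ccccc3)c2)cc(OC)c1CNC(C)C`, the isopropyl analogue, is the only other measured member. In this assay compound 1 gives > 20000 nM, likewise a limit. Going by the values given here, the one measured step, a step that the two limits leave unreadable from compound 1 to compound 2, therefore cannot be read, since both values sit at the limit of > 20000 nM in this assay, at which 2 of the 2 values shown sit. Compound 3 `COc1cc(Oc2cccc(Nc3ccccc3)c2)cc(OC)c1CNCc1ccc(O)cc1` is not yet measured; it differs from compound 2 by 4-hydroxybenzyl in place of cyclopropyl on an amine nitrogen. Among the compounds with values here, no measured step bears on this change, so the expected size of the step in this assay rests on nothing beyond the two limits. The estimate for compound 3 is 20000 nM, with a range from 6000 nM to 60000 nM, most likely again reported only as a limit. The expected step from compound 2 to compound 3 is a number no higher from compound 2 to compound 3 (the limit leaves the size open).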

Compound 3, half-maximal inhibitory concentration: 7940 nM
Compound 3: the middle estimate sits 2.5-fold (0.40 log units) above what was measured, within the range that was stated.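

In this assay, for the compounds shown here, putting 4-hydroxybenzyl on the amine nitrogen gives the only readable steps at this position: an at least 2.5-fold lower number from compound 2 to compound 3 (0.40 log units; beyond the scatter), and an at least 2.5-fold lower number from compound 1 to compound 3 (0.40 log units; beyond the scatter). Both steps show that the substituent on this nitrogen can move the value, which cyclopropyl and isopropyl alone could not show: the limit of > 20000 nM in this assay, at which 2 of the 3 values shown sit. Each step is only a lower bound on size, since compound 1 and compound 2 are held at a limit of the assay and compound 3 alone has a number.

From the compounds shown here alone, it remains open whether the step follows the aromatic ring or the hydroxyl of the 4-hydroxybenzyl group; an unsubstituted benzyl or a 4-methoxybenzyl on the same nitrogen would separate the two. Also open, going by these compounds, is whether a longer chain ending in a hydroxyl would give a similar step.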